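A few compounds are considered here, and "the series" means these few. Any claim that something is new, unique, unknown or untested is made for them only; others in the source may bear on it.

Working notes on the sulfonamide series built on the shared core. Compound 1 `Cc1ccc(S(=O)(=O)Nc2ccc(-c3nc4ccccc4o3)cc2)cc1` carries a methyl group; in an assay on cells for inhibition of HSP60/HSP10 (Homo sapiens), with a stated time of 60 min (on this read-out lower numbers stand for stronger inhibition and higher numbers for weaker inhibition), compound 1 gives only a limit, > 100000 nM, not a number. Compound 2 `O=S(=O)(Nc1ccc(-c2nc3ccccc3o2)cc1)c1ccc(O)cc1` gives 78000 nM in this assay. Compound 3 `COc1ccccc1S(=O)(=O)Nc1ccc(-c2nc3ccccc3o2)cc1` again reaches only a limit in this assay, > 100000 nM. Compound 3 therefore stands at the floor of the read-out, shared with one other member (the limit of > 100000 nM in this assay, at which 2 of the 3 values shown sit). The steps measured so far: an at least 1.2-fold lower number from compound 1 to compound 2 (0.10 log units; that floor lies within the scatter); a step that the two limits leave unreadable from compound 1 to compound 3; an at least 1.2-fold higher number from compound 2 to compound 3 (0.10 log units; that floor lies within the scatter). None of the exchanges of the aryl on the sulfonyl sulfur has moved the read-out beyond the scatter.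

Compound 4 `O=S(=O)(Nc1ccc(-c2nc3ccccc3o2)cc1)c1ccc(Cl)c(Cl)c1` is the next exchange at that position: 3,4-dichlorophenyl in place of 2-methoxyphenyl on a sulfonyl sulfur. For the measured compounds named here, the steps that bear on it are the two earlier exchanges at the sulfonyl sulfur, one unreadable between two limits and one within the scatter, so no measured step gives a direction for this change. The step expected in this assay is a number no higher from compound 3 to compound 4 (the limit leaves the size open), that is, none beyond the scatter, with compound 4 most likely at a limit again. The estimate for compound 4 in this assay is 100000 nM, within 40000 nM to 300000 nM.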

Compound 4, half-maximal inhibitory concentration: 25000 nM
Beside the measured number, compound 4's estimate is 4.0-fold (0.60 log units) above it, outside the stated range (below it).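

The position on the sulfonyl sulfur now responds in this assay: the exchange to 3,4-dichlorophenyl gives the first steps there beyond the scatter, with an at least 4.0-fold lower number from compound 3 to compound 4 (0.60 log units; beyond the scatter), a 3.1-fold lower number from compound 2 to compound 4 (0.49 log units; beyond the scatter) and an at least 4.0-fold lower number from compound 1 to compound 4 (0.60 log units; beyond the scatter). Compound 4 is thus the most potent of the four shown, and the only one whose aryl carries chlorine. Compound 1 and compound 3 remain at a limit, so the steps from them give only a floor on the size: the limit of > 100000 nM in this assay, at which 2 of the 4 values shown sit.

Going by these compounds, whether a single chlorine would carry the same step stays open, since 3,4-dichlorophenyl is the only chlorinated aryl here. Also open, on these data alone, is how an aryl bearing an amine or a carboxylic acid would read out in this assay.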